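The source may report more compounds than this note shows. Statements on the series, on what has been measured and on what is new or still open speak of the compounds shown alone.

Measured compounds:
- compound 1 `O=C(NCc1ccc(S(=O)(=O)c2ccccc2)cc1)N1CCc2ccncc2C1` gives 115000 nM
- compound 2 `O=C(NCc1ccc(S(=O)(=O)c2cncc(C(F)(F)F)c2)cc1)N1Cc2ccncc2C1` gives 83000 nM
- compound 3 `CCCn1cc(S(=O)(=O)c2ccc(CNC(=O)N3Cc4ccncc4C3)cc2)cn1` gives 105000 nM

All three values come from a physicochemical assay for solubility, in phosphate buffer, with a stated time of 24 h, at pH 7.4, tested at 100 uM; on this read-out lower numbers stand for lower solubility and higher numbers for higher solubility. Compound 3 lies within the scatter of both compound 1 and compound 2, so the three values do not separate.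

Compound 4 `O=C(NCc1ccc(S(=O)(=O)C2CCC(F)(F)CC2)cc1)N1Cc2ccncc2C1` has not yet been measured. It differs from compound 3 by 4,4-difluorocyclohexyl in place of 1-propyl-1H-pyrazol-4-yl on a sulfonyl sulfur.

For the measured compounds named here, only one measured step changes the group at this place: a 1.3-fold higher number from compound 2 to compound 3 (0.10 log units; within the scatter). That step, 1-propyl-1H-pyrazol-4-yl in place of 5-(trifluoromethyl)pyridin-3-yl, stays within the scatter. Going by the values given here, compound 1 differs from compound 3 in more than one place, so it gives no clean step. Among the compounds with values here, no measured compound carries a non-aromatic ring on the sulfonyl sulfur, so this swap has not been tested, and the range is kept wide.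

No change beyond the scatter is therefore expected in this assay, and no firm direction can be drawn. The estimated step is a 1.2-fold lower number from compound 3 to compound 4 (0.07 log units; within the scatter), which is expected to stay within the scatter. Compound 4 is estimated at 90000 nM, with an expected range from 45000 nM to 125000 nM.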

Compound 4, solubility: 35000 nM
Compound 4: the middle estimate sits 2.6-fold (0.41 log units) above what was measured, and the stated range ends above it.
By their numbers in this assay, from the lowest: compound 4; then compounds 2, 3 and 1 (each within the scatter of the next).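

In this assay, the group on the sulfonyl sulfur now matters: the earlier change at this place stayed within the scatter (a 1.3-fold higher number from compound 2 to compound 3 (0.10 log units; within the scatter)), whereas the 4,4-difluorocyclohexyl group gives a 3.0-fold lower number from compound 3 to compound 4 (0.48 log units; beyond the scatter). The step is also beyond the scatter against the 5-(trifluoromethyl)pyridin-3-yl group, with a 2.4-fold lower number from compound 2 to compound 4 (0.38 log units; beyond the scatter), so compound 4, the only one here with a non-aromatic ring of carbon only at this place, stands apart from both aromatic partners that differ from it in this one place. No measurement available here accounts for this step.

With a single non-aromatic example, the series does not yet separate any contribution of the ring itself from that of its fluorine atoms, and a plain cyclohexyl group on the same sulfonyl sulfur would address that question directly. Also open, on these data alone, is whether a non-aromatic ring carrying a hydroxyl group or a ring amine, such as a piperidin-4-yl group, would fall with compound 4 or with compound 2 and compound 3.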